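A few compounds are considered here, and "the series" means these few. Any claim that something is new, unique, unknown or untested is made for them only; others in the source may bear on it.

Compound 1 `O=c1cc(-c2ccccc2)oc2ccc(N3COc4ccccc4C3)cc12` gives 68.5% in a functional assay on MCF7 cells (Homo sapiens) for inhibition, read by MTT assay, with a stated time of 48 h, tested at 30 ug/mL; on this read-out lower numbers stand for less inhibition of growth and higher numbers for more inhibition of growth at the one concentration tested. Compound 3 `Cc1ccc2c(c1)CN(c1ccc3oc(-c4ccccc4)cc(=O)c3c1)CO2` gives 56.9% in this assay, and compound 2 `Cc1cccc2c1OCN(c1ccc3c(=O)cc(-c4ccccc4)oc3c1)C2` gives 57.8%; the difference between the cores of compound 2 and compound 3 is not broken down here, and these two values lie within the scatter of each other. Between compound 3 and compound 1 the change is hydrogen in place of methyl on an aromatic carbon, and the step is a number 11.6 percentage points higher from compound 3 to compound 1 (beyond the scatter). Compound 4 `O=c1cc(-c2ccccc2)oc2cc(N3COc4ccccc4C3)ccc12` is not yet measured; it differs from compound 2 by hydrogen in place of methyl on an aromatic carbon, the same kind of change, though here the place is ortho to a fused ring and meta to a fused ring, whereas in the earlier pair it was meta to a fused ring and para to a fused ring. For compound 4 a step of a number 10.2 percentage points higher from compound 2 to compound 4 (beyond the scatter) is expected, resting on the step of a number 11.6 percentage points higher from compound 3 to compound 1 (beyond the scatter). For compound 4 the estimate is 68%, with a range from 58% to 78%.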

Compound 4, percent growth inhibition at one concentration: 12.7%
Estimate against measurement, compound 4: 55.3 percentage points above, and the stated range ends above it.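

In this assay the change from methyl to hydrogen on an aromatic carbon gives a number 45.1 percentage points lower from compound 2 to compound 4 (beyond the scatter) and so does not repeat the earlier result. The change carries over from one core to the other in neither size nor direction: the same change on two cores in this assay, a number 11.6 percentage points higher (beyond the scatter) from compound 3 to compound 1 and a number 45.1 percentage points lower (beyond the scatter) from compound 2 to compound 4, 56.7 percentage points apart, beyond the scatter of two such steps. A step read on one core therefore gives no safe estimate for the other, but two pairs, which also differ in the place of the change, do not show whether the core or the place sets the outcome.

As far as these compounds go, only methyl and hydrogen appear at these places, so the effect of an amine, a methoxy group or a longer chain on either core stays open. Also open, from the compounds shown here alone, is whether either step would hold at other concentrations.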